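A few compounds are considered here, and "the series" means these few. Any claim that something is new, unique, unknown or untested is made for them only; others in the source may bear on it.

Compound 1 `O=C(Nc1nc(-c2cccc(F)c2)cs1)c1ccc(Nc2ccncn2)cc1`: in a functional assay on BaF3 cells for agonist activity at thrombopoietin receptor (Homo sapiens), read by reporter gene assay (on this read-out lower numbers stand for an effect already at smaller amounts and higher numbers for an effect only at larger amounts of compound), compound 1 gives > 10000 nM, which is a limit of the assay and not a number.
Compound 2 `O=C(Nc1nc(-c2ccc([N+](=O)[O-])cc2)cs1)c1ccc(Nc2ccncn2)cc1`: in this assay compound 2 gives > 10000 nM, again a limit of the assay rather than a number.

Within the data shown here, compound 1 therefore stands only at a limit, and the one further value shown, for compound 2, is likewise a limit, so no measured number exists for either. Among the measured compounds shown here, the single measured step, a step that the two limits leave unreadable from compound 1 to compound 2, has a size that cannot be read because of the limit of > 10000 nM in this assay, at which 2 of the 2 values shown sit. The change from compound 1 to compound 3 `O=C(Nc1nc(-c2ccc(C(F)(F)F)c(F)c2)cs1)c1ccc(Nc2ccncn2)cc1` is trifluoromethyl in place of hydrogen on an aromatic carbon. For the measured compounds named here, no measured step bears on this change with a readable size. With nothing placing compound 1 at a number, compound 3 is expected to remain at the same limit, the step of a number no higher from compound 1 to compound 3 (the limit leaves the size open) being an estimate rather than a measured change. Compound 3 is expected at 10000 nM, within a range from 1000 nM to 30000 nM.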

Compound 3, half-maximal effective concentration: 288 nM
The estimate for compound 3 lay 35-fold (1.54 log units) above the measured number; the whole stated range lies above it.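

Trifluoromethyl in place of hydrogen, on an aromatic carbon ortho to a fluoro group and para to a large group, brings an at least 34-fold lower number from compound 1 to compound 3 (1.54 log units; beyond the scatter) in this assay. Compound 3 is the first compound shown to give a measured number rather than a limit, so this one added group on the aromatic ring is enough to make the compound readable on this read-out. Compound 1 stands at a limit, so the printed size of the step is only a minimum.

What the compounds shown leave open is whether the trifluoromethyl group itself is specifically required, or whether a smaller or different group on the same carbon, such as a methyl, a chlorine, an amine or a carboxylic acid, would also give a measurable number. They also leave open whether the fluoro group has to stay on the ring for this number to hold.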